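Amine substituent change in a weak caspase-8 inhibitor series

The source may report more compounds than this note shows. Statements on the series, on what has been measured and on what is new or still open speak of the compounds shown alone.

Compound 3 `CCC(C(=O)N[C@@H](CC(=O)O)C(=O)CNCN1CCCC1)n1ccnc(NCc2nonc2C)c1=O` is measured in an assay for inhibition of Caspase-8 (Homo sapiens) (a higher number here means a weaker inhibitor, a lower number a stronger inhibitor), where compound 3 gives 6220 nM. Among the two numbers shown it is the lowest; its nearest neighbour, compound 1 `CCC(C(=O)N[C@@H](CC(=O)O)C(C)=O)n1cc(C(C)(C)C)nc(NCc2nonc2C)c1=O`, gives 10000 nM in this assay, and the gap between the two lies within the scatter. Compound 2 `CCCCCCN(C)CNCC(=O)[C@H](CC(=O)O)NC(=O)C(CC)n1ccnc(NCc2nonc2C)c1=O` returns only a limit of the assay, > 10000 nM, in this assay. Going by the values given here, the one step that varies the same part of the molecule is an at least 1.6-fold lower number from compound 2 to compound 3 (0.20 log units; that floor lies within the scatter), which touches the limit of > 10000 nM in this assay, at which 1 of the 3 values shown sits, and therefore gives only a floor.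

Compound 4 `CCC(C(=O)N[C@@H](CC(=O)O)C(=O)CNCN1Cc2ccccc2C1)n1ccnc(NCc2nonc2C)c1=O` differs from compound 3 by a group of 9 heavy atoms (8 carbon, 1 nitrogen; one five-membered non-aromatic ring with 1 hetero atom, one six-membered aromatic ring of carbon only) in place of a group of 5 heavy atoms (4 carbon, 1 nitrogen; one five-membered non-aromatic ring with 1 hetero atom), on a saturated chain carbon bound to an amine nitrogen. Among the compounds with values here, since the only measured step at that position sits within the scatter, no step beyond the scatter is expected from compound 3 to compound 4 in this assay, in either direction. Compound 4 is therefore estimated at 5000 nM, within a range from 1500 nM to 15000 nM, which corresponds to an expected step of a 1.2-fold lower number from compound 3 to compound 4 (0.09 log units; within the scatter).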

Compound 4, half-maximal inhibitory concentration: 4290 nM
Beside the measured number, compound 4's estimate is 1.2-fold (0.07 log units) above it; the range from low to high includes it.
By their numbers in this assay, from the lowest: compounds 4, 3 and 1 (each within the scatter of the next, the first and the last beyond it).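

In this assay, the added six-membered aromatic ring of carbon only does not move the number beyond the scatter, with a 1.4-fold lower number from compound 3 to compound 4 (0.16 log units; within the scatter) on a saturated chain carbon bound to an amine nitrogen, so this position accepts the larger group of 9 heavy atoms. Set against the open hexyl(methyl)amino group, the same group gives an at least 2.3-fold lower number from compound 2 to compound 4 (0.36 log units; beyond the scatter), the first step at this position that clears the scatter. That step is only a floor, since compound 2 is a limit of the assay: the limit of > 10000 nM in this assay, at which 1 of the 4 values shown sits.

The compounds shown leave open whether the aromatic ring matters at all or any cyclic amine serves equally well. A piperidine or a morpholine in the same place would bear on that, as would a methoxy group on the aromatic ring.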